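Piperazine aryl variation on the bicyclic sulfonamide series

A few compounds are considered here, and "the series" means these few. Any claim that something is new, unique, unknown or untested is made for them only; others in the source may bear on it.

Measured compounds:
compound 1 `CC1(C)[C@@H]2CC[C@@]1(CS(=O)(=O)N1C[C@@H]3C[C@H]1CN3c1ccc(C(F)(F)F)cn1)C(=O)C2`, > 31600 nM
compound 2 `CC1(C)[C@@H]2CC[C@@]1(CS(=O)(=O)N1CCN(c3ccccn3)CC1)C(=O)C2`, > 31600 nM
compound 3 `CC1(C)[C@@H]2CC[C@@]1(CS(=O)(=O)N1CCN(c3nc(Cl)c(C(F)(F)F)cc3Cl)CC1)C(=O)C2`, 316 nM

In a functional assay on CHO-K1 cells for antagonist activity at C-X-C chemokine receptor type 3 (Homo sapiens), read by FLIPR and calcium flux (a higher number here means a weaker inhibitor, a lower number a stronger inhibitor), compound 1 returns only a limit, > 31600 nM. Compound 2 likewise returns only a limit, > 31600 nM. Compound 3 gives a number, 316 nM. For the measured compounds named here, compound 2 therefore stands at the limit of > 31600 nM in this assay, at which 2 of the 3 values shown sit, together with compound 1, and the only number in the set belongs to compound 3, whose ring on the amine nitrogen carries additional groups. Going by the values given here, no step between two measured compounds can be computed.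

Compound 4 `CC1(C)[C@@H]2CC[C@@]1(CS(=O)(=O)N1CCN(c3cc4ccccc4cn3)CC1)C(=O)C2` differs from compound 2 as follows: isoquinolin-3-yl in place of pyridin-2-yl on an amine nitrogen in a ring. Nothing measured fixes where compound 4 falls.

Compound 2 sits at the limit. Compound 3 reaches 316 nM. For compound 4 the estimated step is an at least 3.1-fold lower number from compound 2 to compound 4 (0.49 log units; beyond the scatter), which takes it below the limit while leaving it well short of compound 3. The estimate for compound 4 is 10000 nM, within 1500 nM to 40000 nM, with a real chance that only a limit is reported again.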

Compound 4, half-maximal inhibitory concentration: 15800 nM
Beside the measured number, compound 4's estimate is 1.6-fold (0.20 log units) below it; low and high end bracket the measured number.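

In this assay, placing isoquinolin-3-yl instead of pyridin-2-yl on the amine nitrogen in the ring gives an at least 2.0-fold lower number from compound 2 to compound 4 (0.30 log units; that floor lies within the scatter). This shows that an added six-membered aromatic ring of carbon only is compatible with a measurable value at this position, without the additional ring groups present on compound 3, though the printed floor alone does not establish a change beyond the scatter. Compound 2 returns only a limit, so the full size of the step cannot be read: the limit of > 31600 nM in this assay, at which 2 of the 4 values shown sit.

The compounds shown leave open whether the ring nitrogen of isoquinolin-3-yl is needed, which a naphthalen-2-yl group on the same amine nitrogen would address. They also leave open whether chlorine or trifluoromethyl on isoquinolin-3-yl would add to the effect of the larger ring system, or whether a more polar substituent there, such as an amine or a carboxylic acid, would be tolerated.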